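The compounds below may be only part of what the source reports. "The series", "measured", "known", "first", "only" and "open" are said of these compounds alone.

Of the compounds shown here, two have so far been tested in an assay on HEK293 cells for inhibition of acid ceramidase (Homo sapiens), read by fluorescence, with stated times of 10 min and 3 h; on this read-out lower numbers stand for stronger inhibition and higher numbers for weaker inhibition. Compound 1, `CC(C)N1CCN(c2ccc3c(c2)oc(=O)n3C(=O)NCCCCc2ccccc2)CC1`, gives 211 nM in this assay. Compound 2, `CC(=O)N1CCc2oc(=O)n(C(=O)NCCCCc3ccccc3)c2C1`, gives 293 nM in this assay. Of these two numbers compound 1 has the lower one, but the gap to compound 2 lies within the usual scatter of repeated measurements, so on these data the two cannot be told apart.

Compound 3, `CC(C)CN1CCC(c2ccc3c(c2)oc(=O)n3C(=O)NCCCCc2ccccc2)CC1`, has not yet been measured. It differs from compound 1 in a single place: 1-isobutylpiperidin-4-yl in place of 4-isopropylpiperazin-1-yl on an aromatic carbon. One six-membered non-aromatic ring carrying a branched chain is thus exchanged for another six-membered non-aromatic ring carrying a branched chain, at the same aromatic carbon of the shared core.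

For the measured compounds named here, no pair of measured compounds shows a comparable exchange, so there is no direct guide to how large the step will be. The expected step from compound 1 to compound 3 is a 1.0-fold higher number from compound 1 to compound 3 (0.02 log units; within the scatter), which means no change beyond the scatter. Compound 3 is therefore expected to give roughly 220 nM in this assay, within a range from 70 nM to 700 nM.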

Compound 3, half-maximal inhibitory concentration: 120 nM
Compound 3: middle estimate off by 1.8-fold (0.26 log units), on the high side; the measured number falls inside the stated range.
By their numbers in this assay, from the lowest: compounds 3, 1 and 2 (each within the scatter of the next, the first and the last beyond it).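

In this assay putting 1-isobutylpiperidin-4-yl in place of 4-isopropylpiperazin-1-yl on this aromatic carbon gives a 1.8-fold lower number from compound 1 to compound 3 (0.25 log units; within the scatter) and so leaves the two compounds indistinguishable. For the compounds shown here, this is the first comparison in which only one place differs, and it shows that this aromatic carbon can carry a ring with 1 hetero atom and 1 hydrogen-bond acceptor as well as one with 2 of each, with no change beyond the scatter. No separate measurement is available to explain why these two groups give such similar results.

Going by these compounds, the ring and its branched chain change together in this single step, so the contribution of each remains unknown. Also open, on these data alone, is how the number would respond at this aromatic carbon to a piperidin-4-yl ring with only a hydrogen on its nitrogen, to a straight butyl chain on that nitrogen, or to a morpholine ring.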